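The source may report more compounds than this note shows. Statements on the series, on what has been measured and on what is new or still open speak of the compounds shown alone.

Measured so far in an assay for inhibition of acyl-CoA:cholesterol acyltransferase (Oryctolagus cuniculus), using microsomes; a higher number here means a weaker inhibitor, a lower number a stronger inhibitor:
compound 1, `COc1cc(C)nc(OC)c1NC(=O)N(Cc1ccc(Oc2ccc(F)cc2)cc1)C1CCCCCC1`, gives 33 nM;
compound 2, `CSc1nc(C)cc(Cl)c1NC(=O)N(Cc1ccc(Oc2ccc(F)cc2)cc1)C1CCCCCC1`, gives 12 nM;
compound 3, `Cc1cc(C)c(NC(=O)N(Cc2ccc(Oc3ccc(F)cc3)cc2)C2CCCCCC2)c(C)n1`, gives 62 nM.

Among these three, compound 3 has the highest number, meaning the weakest inhibition. Its nearest neighbour is compound 1, and that gap, a 1.9-fold higher number from compound 1 to compound 3 (0.27 log units; within the scatter), stays inside the usual scatter. The gap to compound 2, a 5.2-fold higher number from compound 2 to compound 3 (0.71 log units; beyond the scatter), is modest but real.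

Compound 4, `Cc1ccc(NC(=O)N(Cc2ccc(Oc3ccc(F)cc3)cc2)C2CCCCCC2)c(Cl)n1`, has not yet been measured. The change from compound 3 is 2-chloro-6-methylpyridin-3-yl in place of 2,4,6-trimethylpyridin-3-yl on an amide-type nitrogen. Among the compounds with values here, two measured steps bear on this. Compound 2, whose ring also carries a chlorine and a methyl, gives the lowest number of the set, and the step of a 2.8-fold lower number from compound 1 to compound 2 (0.44 log units; beyond the scatter) as well as the step of a 5.2-fold higher number from compound 2 to compound 3 (0.71 log units; beyond the scatter) point the same way. Compound 4 is therefore expected to give a number somewhat lower than compound 3, estimated as a 2.1-fold lower number from compound 3 to compound 4 (0.32 log units; beyond the scatter) in this assay. The estimate for compound 4 is 30 nM, with a range from 12 nM to 80 nM.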

Compound 4, half-maximal inhibitory concentration: 19 nM
Compound 4: the middle estimate sits 1.6-fold (0.20 log units) above what was measured; the range from low to high includes it.
By their numbers in this assay, from the lowest: compounds 2, 4, 1 and 3 (each within the scatter of the next, the first and the last beyond it).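

In this assay, the change on the amide-type nitrogen gives a 3.3-fold lower number from compound 3 to compound 4 (0.51 log units; beyond the scatter) and shows that a chlorine-bearing ring can give a lower number than the 2,4,6-trimethylpyridin-3-yl group without the sulfur-containing group of compound 2. That sulfur-containing group is not needed to stay close to compound 2: the step of a 1.6-fold higher number from compound 2 to compound 4 (0.20 log units; within the scatter) lies within the scatter, even though 2-chloro-6-methylpyridin-3-yl is the smallest ring group here by heavy atoms. The step of a 1.7-fold lower number from compound 1 to compound 4 (0.24 log units; within the scatter) also lies within the scatter, so this assay does not separate the new group from the oxygen-bearing ring group of compound 1.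

Nothing available accounts for the drop from compound 3 to compound 4. From the compounds shown here alone, whether the chlorine itself matters remains open, and a 2-fluoro-6-methylpyridin-3-yl or 2-amino-6-methylpyridin-3-yl group would put that to the test.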